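The source may hold more compounds than are shown below. What is called first, only, known or untested is meant among the compounds shown, and "the series" means these compounds.

Compound 1 `COc1cc(-n2cnc3ccc(-c4ccc(C(C)=O)cc4)cc32)cc(OC)c1OC` carries a 4-acetylphenyl group on its shared core. In a functional assay on SGC-7901 cells (Homo sapiens) for antiproliferative activity, read by MTT assay, with a stated time of 72 h (a higher number here means a weaker inhibitor, a lower number a stronger inhibitor), compound 1 gives 450 nM. Among the two values shown, this is the only plain number; the other is a limit of the assay. Compound 2 `COc1cc(-n2cnc3ccc(-c4ccc(Cl)cc4Cl)cc32)cc(OC)c1OC` bears 2,4-dichlorophenyl in the same position. In this assay compound 2 gives only a limit, > 10000 nM. The step of an at least 22-fold higher number from compound 1 to compound 2 (1.34 log units; beyond the scatter) therefore rests on a limit, as the limit of > 10000 nM in this assay, at which 1 of the 2 values shown sits, records, and shows that exchanging the 4-acetylphenyl group can weaken inhibition strongly.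

Compound 3 `COc1cccc(-c2ccc3ncn(-c4cc(OC)c(OC)c(OC)c4)c3c2)c1` has not yet been measured. The change from compound 1 is 3-methoxyphenyl in place of 4-acetylphenyl on an aromatic carbon. Within the data shown here, the only measured step that bears on it is the one from compound 1 to compound 2, which also replaced 4-acetylphenyl and was large. The entering group here differs from that one, so the direction is taken from that step but with a wide spread. The expected step of a 3.3-fold higher number from compound 1 to compound 3 (0.52 log units; beyond the scatter) is thus a weakening, of uncertain size. Compound 3 is estimated to give 1500 nM, with a range from 300 nM to 8000 nM.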

Compound 3, half-maximal inhibitory concentration: 3310 nM
Beside the measured number, compound 3's estimate is 2.2-fold (0.34 log units) below it, and the stated range covers the measured number.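

Compound 3 shows that 4-acetylphenyl can be replaced at this position with the result still a plain number in this assay, so the cost of such an exchange can now be sized without relying on a limit: a 7.4-fold higher number from compound 1 to compound 3 (0.87 log units; beyond the scatter). The entering group also matters, as two different replacements of 4-acetylphenyl give different results, with 3-methoxyphenyl in place of 2,4-dichlorophenyl giving an at least 3.0-fold lower number from compound 2 to compound 3 (0.48 log units; beyond the scatter). That second step, which places compound 3 between the other two, has only a lower bound on its size, as it rests on a limit: the limit of > 10000 nM in this assay, at which 1 of the 3 values shown sits.

The 4-acetylphenyl and 3-methoxyphenyl groups differ both in their substituent and in where it sits on the phenyl ring, so these compounds cannot separate the two effects, and 4-methoxyphenyl, which would keep the substituent of compound 3 at the ring position of compound 1, would be the direct test. Also open, going by these compounds, is how a phenyl ring carrying an amine or a carboxylic acid would behave at this position.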